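A few compounds are considered here, and "the series" means these few. Any claim that something is new, unique, unknown or untested is made for them only; others in the source may bear on it.

Measured so far:
Compound 1, `Cc1ccc2c(c1)CCN2S(=O)(=O)c1ccc(-c2cnc(C3CC3)o2)cc1`: in a functional assay on Jurkat cells (Homo sapiens) for inhibition, read by MTT assay, tested at 10 uM (a higher number here means more inhibition at the concentration tested (going by the name of the read-out), a lower number less inhibition), compound 1 gives 91.1%
Compound 2, `N#Cc1ccc2c(c1)CCN2S(=O)(=O)c1ccc(-c2cnc(C3CC3)o2)cc1`: in this assay compound 2 gives 15.8%

Compound 2 stands lowest of the two numbers in this assay. Its nearest neighbour is compound 1, and the two are separated by a number 75.3 percentage points lower from compound 1 to compound 2 (beyond the scatter), a change that lies well outside the usual scatter of this kind of measurement.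

Compound 3, `O=S(=O)(c1ccc(-c2cnc(C3CC3)o2)cc1)N1CCc2cc(F)ccc21`, is the next compound to be measured in this assay. It differs from compound 2 in one place: fluoro in place of cyano on an aromatic carbon. Among the measured compounds shown here, the only measured step that bears on this is a number 75.3 percentage points lower from compound 1 to compound 2 (beyond the scatter), which swaps the group on the same aromatic carbon; putting cyano there went along with a large drop in inhibition. Compound 3 removes that cyano again and puts fluoro in its place. For the measured compounds named here, no measured compound carries fluoro at this position, so the size of the effect cannot be read directly from the data, but the direction is expected to be upward. The expected step is a number 39.2 percentage points higher from compound 2 to compound 3 (beyond the scatter), a rise beyond the scatter, with wide uncertainty. For compound 3 the estimate in this assay is 55%, within a range from 20% to 90%.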

Compound 3, a percentage reported as inhibition, at one concentration (the size of the read-out at that concentration, not a potency): 24.3%
Compound 3: middle estimate off by 30.7 percentage points, on the high side, within the range that was stated.
By their numbers in this assay, from the lowest: compounds 2 and 3 (each within the scatter of the next); then compound 1.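

In this assay, fluoro in place of cyano gives a number 8.5 percentage points higher from compound 2 to compound 3 (within the scatter), so compound 2 and compound 3 cannot be told apart, and removing the cyano did not by itself bring the inhibition back. Fluoro in place of methyl gives a number 66.8 percentage points lower from compound 1 to compound 3 (beyond the scatter), a loss of nearly the same size as a number 75.3 percentage points lower from compound 1 to compound 2 (beyond the scatter). The large loss is therefore not peculiar to cyano: on this aromatic carbon, two quite different replacements for methyl both end far from compound 1, and among these three compounds only the methyl compound reaches a high number. Nothing available here explains why this position responds in this way.

The compounds shown leave open whether methyl is unique at this aromatic carbon, or whether an ethyl, a chloro or a methoxy group would also keep the inhibition high, and what a plain hydrogen there would give. From the compounds shown here alone, every comparison so far sits at this one place, so it also remains open whether the same preference for methyl would hold with a different group elsewhere on the shared core, such as an isopropyl in place of the cyclopropyl.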